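Aryl sulfonate anilides: amide to urea exchange

The source may hold more compounds than are shown below. What is called first, only, known or untested is meant among the compounds shown, and "the series" means these compounds.

Measured compounds in a functional assay on HT-29 cells (Homo sapiens) for antiproliferative activity, read by sulforhodamine B assay, with a stated time of 48 h; on this read-out lower numbers stand for stronger inhibition and higher numbers for weaker inhibition:
Compound 1, `CC(=O)Nc1cccc(S(=O)(=O)Oc2ccccc2C(C)C)c1`, gives 27000 nM.
Compound 2, `CCCC(=O)Nc1ccc(S(=O)(=O)Oc2ccccc2I)cc1`, gives 11000 nM.
Compound 3, `CCCNC(=O)Nc1ccc(S(=O)(=O)Oc2ccccc2C(C)C)cc1`, gives 6300 nM.

Compound 2 stands second highest of the three numbers. Its nearest neighbour is compound 3, whose number lies lower but within the usual scatter, so no order between these two can be read. Its furthest neighbour is compound 1, whose number lies higher, beyond the scatter. For the measured compounds named here, no two measured compounds differ in only one place, so no single step is available to calibrate the next change.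

Compound 4, `O=C(Nc1ccc(S(=O)(=O)Oc2ccccc2I)cc1)NC1CC1`, is not yet measured. It differs from compound 2 as follows: cyclopropylamino in place of propyl on a carbonyl carbon. The exchange keeps the iodo-bearing ring and the sulfonate linkage of compound 2 intact and alters only the group on the carbonyl carbon.

With no measured step of this kind in the series, the expectation rests on the closeness of compound 2 and compound 3 in this assay. The step of a 1.6-fold lower number from compound 2 to compound 4 (0.20 log units; within the scatter) is expected to be small, toward a lower number, and to stay near the edge of the scatter rather than beyond it. Compound 4 is estimated at 7000 nM, with a range from 2500 nM to 20000 nM.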

Compound 4, half-maximal inhibitory concentration: 14000 nM
Compound 4: the middle estimate sits 2.0-fold (0.30 log units) below what was measured; the range from low to high includes it.
By their numbers in this assay, from the lowest: compounds 3, 2, 4 and 1 (each within the scatter of the next, the first and the last beyond it).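

In this assay, the exchange of propyl for cyclopropylamino on a carbonyl carbon gives a 1.3-fold higher number from compound 2 to compound 4 (0.10 log units; within the scatter), so this position accepts a nitrogen and a three-membered ring together without a step that can be told from repeat measurement. For the compounds shown here, this is the first single-place step; the earlier compounds offered only values across differences in more than one place, and so gave no reading for any one position. The step holds for this one pair on the iodo-bearing scaffold of compound 2 and says nothing yet about the same exchange on any other member of the series, and no available measurement accounts for the result.

Since the nitrogen and the three-membered ring enter in one step, the compounds shown do not separate what each contributes. As far as these compounds go, whether the position stays this flat with larger or differently substituted groups on the same carbonyl carbon, such as cyclohexylamino or dimethylamino, remains open, as does whether any group there can produce a step beyond the scatter.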